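Trimming a methoxy from a carbamate side chain

The source may report more compounds than this note shows. Statements on the series, on what has been measured and on what is new or still open speak of the compounds shown alone.

compound 1, `CCN(CC)c1cc2[nH]c(C3CCCCC3)nc2cc1NC(=O)c1ccc(OC(F)F)cc1`: > 100 ug/mL
compound 2, `CCN(CC)c1cc2[nH]c(C3CCCCC3)nc2cc1NC(=O)OCCOCCOC`: > 100 ug/mL

Both compounds were tested in an ADME assay on Vero cells (Chlorocebus sabaeus) for cytotoxicity, read by resazurin assay, with a stated time of 3 days; on this read-out higher numbers stand for weaker inhibition and lower numbers for stronger inhibition. For compound 1 the value > 100 ug/mL is a limit of the assay, not a number. For compound 2 the value > 100 ug/mL is likewise a limit. Among the measured compounds shown here, the one measured step, a step that the two limits leave unreadable from compound 1 to compound 2, runs between two such limits and so has no readable size. Compound 2 therefore stands where every value shown stands: at the limit of > 100 ug/mL in this assay, at which 2 of the 2 values shown sit.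

Compound 3, `CCOCCOC(=O)Nc1cc2nc(C3CCCCC3)[nH]c2cc1N(CC)CC`, differs from compound 2 by hydrogen in place of methoxy on a saturated chain carbon, two bonds along the chain from an oxygen on a saturated carbon. For the measured compounds named here, no measured step bears on this change with a readable size, since the only step available is the unreadable one just described. With nothing pointing to a shift in either direction, the step from compound 2 to compound 3 is expected to be a step that the limit leaves unreadable from compound 2 to compound 3, that is, none beyond the scatter. Compound 3 is estimated at 150 ug/mL in this assay, within a range from 70 ug/mL to 400 ug/mL, and most likely reported again as a limit.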

Compound 3, half-maximal inhibitory concentration: > 100 ug/mL
Compound 3 gave a limit, no number (the forecaster's own chance of this, stated with the estimate: 85%); the middle value does not contradict the limit.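

Neither compound 2 nor compound 1 gives a readable step to compound 3, because in this assay all three results are limits, not numbers: the limit of > 100 ug/mL in this assay, at which 3 of the 3 values shown sit.

The compounds shown leave open whether swapping these side chains shifts cytotoxicity at all, and what actual numbers compound 1, compound 2 and compound 3 would have.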